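The compounds below may be only part of what the source reports. "The series", "measured", "known", "first", "only" and "open" are said of these compounds alone.

Compound 2 `COc1cc2nnc(C(N)=O)c(Nc3ccc(C)cc3F)c2cc1N1C[C@@H](C)N[C@@H](C)C1` gives 61% in an ADME assay on the whole organism for pharmacokinetics, with Rattus norvegicus as the target, at a dose of 10 mg/kg by the oral route (on this read-out lower numbers stand for lower oral bioavailability and higher numbers for higher oral bioavailability), the lowest of the two numbers in hand; compound 1 `COc1cc2nnc(C(N)=O)c(Nc3ccc(C)cc3F)c2cc1N1CCN(C(C)C)CC1` gives 100%. Within the data shown here, the one step between measured compounds, a number 39 percentage points lower from compound 1 to compound 2 (beyond the scatter), changes the same position that compound 3 `COc1cc2nnc(C(N)=O)c(Nc3ccc(C)cc3F)c2cc1N1CCC(N(C)C)CC1` alters again: 4-(dimethylamino)piperidin-1-yl in place of 3,5-dimethylpiperazin-1-yl on an aromatic carbon. That step was large and downward. The change to compound 3 moves back toward a group without a ring hydrogen-bond donor, as in compound 1, and so for compound 3 the expected step is a number 19 percentage points higher from compound 2 to compound 3 (beyond the scatter), smaller than the earlier step and less certain. Compound 3 is therefore estimated at 80%, with a range of 55% to 100%.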

Compound 3, oral bioavailability: 15%
The estimate for compound 3 lay 65 percentage points above the measured number; the measured number lies below the stated range.
By their numbers in this assay, from the lowest: compound 3; then compound 2; then compound 1.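

In this assay, 4-(dimethylamino)piperidin-1-yl on this aromatic carbon, with 0 hydrogen-bond donors, gives a number 46 percentage points lower from compound 2 to compound 3 (beyond the scatter), so dropping the ring hydrogen-bond donor of 3,5-dimethylpiperazin-1-yl does not by itself raise the number. Against 4-isopropylpiperazin-1-yl the same group gives a number 85 percentage points lower from compound 1 to compound 3 (beyond the scatter), so two groups without that ring donor stand at opposite ends of the three compounds. Nothing available accounts for these steps. Open, going by these compounds, is whether 4-(isopropylamino)piperidin-1-yl or 4-ethylpiperazin-1-yl would stay nearer compound 1 or compound 3, which would help separate the effect of the ring from that of the amine substituent.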